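A few compounds are considered here, and "the series" means these few. Any claim that something is new, unique, unknown or untested is made for them only; others in the source may bear on it.

Compound 1 `CCCC1=C(C(=O)OCC2CCCCC2)C(c2cccc(O)c2)NC(=O)N1`, with a propyl chain on the shared core, gives > 10000 nM in an ADME assay on CEMx174 cells (Homo sapiens) for cytotoxicity (on this read-out higher numbers stand for lower toxicity in this test and lower numbers for higher toxicity in this test), and this is a limit of the assay, not a number. For compound 2 `CC(C)C1=C(C(=O)OCC2CCCCC2)C(c2cccc(O)c2)NC(=O)N1`, the result reads "not determined" (no result reported). Compound 3 `CCC1=C(C(=O)OCC2CCCCC2)C(c2cccc([N+](=O)[O-])c2)NC(=O)N1` gives > 10000 nM, which is again only a limit. Compound 3 therefore stands at the limit of > 10000 nM in this assay, at which 2 of the 3 values shown sit. Compound 4 `CCC1=C(C(=O)OCC2CCCCC2)C(c2ccc(N)cc2)NC(=O)N1` has 4-aminophenyl in place of the 3-nitrophenyl of compound 3 on a saturated ring carbon: 4-aminophenyl in place of 3-nitrophenyl on a saturated ring carbon. Going by the values given here, no measured pair shows what a single change does here, so the expectation rests on (the limit of > 10000 nM in this assay, at which 2 of the 3 values shown sit), and no shift beyond the usual scatter is expected. The estimated step is a step that the limit leaves unreadable from compound 3 to compound 4. Compound 4 is expected at 15000 nM, with an estimated range of 6000 nM to 50000 nM.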

Compound 4, half-maximal cytotoxic concentration: > 10000 nM
Compound 4: a limit, no number; the forecaster's own chance of this, stated with the estimate: 70%; the middle value lies beyond the limit too.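

Compound 3 and compound 4 both end at a limit in this assay, so no step between them can be read: the limit of > 10000 nM in this assay, at which 3 of the 4 values shown sit.

The compounds shown leave open how much 4-aminophenyl in place of 3-nitrophenyl changes the read-out, and at what concentration any of these compounds becomes toxic to the cells.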